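This account rests on a few compounds, and the source may have more. Where it says the series, first, only, none or still open, it means among the compounds named here.

Measured in an ADME assay on liver for metabolic stability, with Liver microsome (Homo sapiens) as the target, read by LC-MS, using microsomes; a higher number here means faster removal of the compound, a lower number slower removal:

Compound 1, `O=C(NCc1cc(Cl)ccc1-n1cnnn1)[C@@H]1CC=NN1C(=O)[C@H](O)c1ccccc1`, gives < 12 mL.min-1.g-1, which is a limit of the assay and not a number.
Compound 2, `CC(C)(C)C[C@@H](O)C(=O)N1N=CC[C@H]1C(=O)NCc1cc(Cl)ccc1-n1cnnn1`, gives 22 mL.min-1.g-1.
Compound 3, `O=C(NCc1cc(Cl)ccc1-n1cnnn1)[C@@H]1CCON1C(=O)[C@H](O)c1ccccc1`, gives < 12 mL.min-1.g-1, again a limit of the assay rather than a number.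

Compound 1 and compound 2 share one core and differ in a single place: neopentyl in place of phenyl on a saturated chain carbon bound to a carbonyl carbon and an oxygen on a saturated carbon. That change produced an at least 1.8-fold higher number from compound 1 to compound 2 (0.26 log units; that floor lies within the scatter). Compound 1 sits at the assay limit, so only the floor of that step is known; the limit of < 12 mL.min-1.g-1 in this assay, at which 2 of the 3 values shown sit, shows how common that limit is among these values. Compound 3 is built on a different core, and the difference between the cores of compound 1 and compound 3 is not broken down here.

Compound 4, `CC(C)(C)C[C@@H](O)C(=O)N1OCC[C@H]1C(=O)NCc1cc(Cl)ccc1-n1cnnn1`, has not yet been measured in this assay. It stands to compound 3 exactly as compound 2 stands to compound 1: neopentyl in place of phenyl on a saturated chain carbon bound to a carbonyl carbon and an oxygen on a saturated carbon. This is the same change, made at the same place, and it occurs in two pairs among the compounds shown. For the measured compounds named here, for compound 4 the expected step is an at least 1.6-fold higher number from compound 3 to compound 4 (0.22 log units; that floor lies within the scatter), resting on the single measured example, which gave an at least 1.8-fold higher number from compound 1 to compound 2 (0.26 log units; that floor lies within the scatter). The starting point is itself only a limit, so the expectation is loose. Compound 4 is accordingly expected to give 20 mL.min-1.g-1 in this assay, with the likely range running from 10 mL.min-1.g-1 to 40 mL.min-1.g-1.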

Compound 4, intrinsic clearance in microsomes: < 12 mL.min-1.g-1
Compound 4 ended at the assay's limit; the forecaster's own chance of this, stated with the estimate: 30%; middle value at least 1.6-fold (0.22 log units) away from the limit.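

The step from compound 3 to compound 4 cannot be read, because both compounds sit at the same assay limit, which gives no actual number for either: the limit of < 12 mL.min-1.g-1 in this assay, at which 3 of the 4 values shown sit.

The compounds shown leave open what the true numbers for compound 3 and compound 4 are in this assay, and whether neopentyl in place of phenyl has an effect of the same size on the core of compound 3 as on the core of compound 1.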